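Removing propoxycarbonyl from the plasma-stable compound 2

The source may hold more compounds than are shown below. What is called first, only, known or untested is meant among the compounds shown, and "the series" means these compounds.

Measured in an ADME assay on a cell-free system (plasma, Homo sapiens) for metabolic stability, read by LC-MS; a higher number here means that the compound lasts longer, a lower number that the compound disappears faster:
- compound 1 `COCCOC(=O)c1ccc(F)c(C(=O)Nc2cccc(-c3cc(C(=O)Nc4ccncc4F)ccc3CN)c2)c1`: < 0.0834 h (a limit)
- compound 2 `CCCOC(=O)c1ccc(NC(=O)c2cccc(-c3cc(C(=O)Nc4ccncc4F)ccc3CN)c2)cc1`: > 2 h (a limit)

Compound 2 gives > 2 h, which is a limit and not a number. From the compounds shown here alone, it is the upper of the two results in this assay, and its true half-life remains unknown. Compound 1 gives < 0.0834 h, which is also a limit. Within the data shown here, the two compounds differ in more than one place, and no single-change step between measured compounds is available.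

Compound 3 `NCc1ccc(C(=O)Nc2ccncc2F)cc1-c1cccc(C(=O)Nc2ccccc2)c1` carries hydrogen in place of propoxycarbonyl on an aromatic carbon, so that 4-(propoxycarbonyl)phenyl becomes phenyl. The change is para to a large group.

Among the measured compounds shown here, with no measured step to draw on, the expectation starts from compound 2 at > 2 h. A small upward move or none beyond the scatter is expected in this assay, and the assay may again report only a limit. The expected step is a step that the limit leaves unreadable from compound 2 to compound 3. The estimated half-life of compound 3 is 4 h, with an expected range of 2 h to 12 h.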

Compound 3, half-life: > 2 h
Compound 3 ended at the assay's limit; the forecaster's own chance of this, stated with the estimate: 80%; the middle value is on the limit's open side.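

No step from compound 2 to compound 3 can be read in this assay, as both compounds sit at the same limit: the limit of > 2 h in this assay, at which 2 of the 3 values shown sit.

The compounds shown leave open the true half-lives of compound 2 and compound 3, and whether replacing propoxycarbonyl with hydrogen changes plasma half-life at all.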